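The compounds below may be only part of what the source reports. "The series", "measured", "known", "first", "only" and "open" are said of these compounds alone.

Measured compounds:
compound 1 `CCOC(=O)c1ccc(NC(=O)NCc2cc[nH]n2)cc1`: 69000 nM
compound 2 `O=C(NCc1cn[nH]c1)Nc1ccc(S(=O)(=O)c2ccc(Cl)cc2)cc1`: 23 nM
compound 3 `O=C(NCc1cn[nH]c1)Nc1ccc(S(=O)(=O)c2ccccc2)cc1`: 28 nM

In an assay on isolated protein for activation of Nicotinamide phosphoribosyltransferase (Homo sapiens) (on this read-out higher numbers stand for an effect only at larger amounts of compound and lower numbers for an effect already at smaller amounts), compound 1 stands at the highest of the three numbers; the values of compound 3 and compound 2 lie far lower, in both cases beyond the scatter. For the measured compounds named here, the single step between measured compounds, a 1.2-fold higher number from compound 2 to compound 3 (0.09 log units; within the scatter), concerns another part of the shared core and stayed within the scatter. Compound 4 `CCOC(=O)c1ccc(NC(=O)NCc2c[nH]nn2)cc1` differs from compound 1 by 1H-1,2,3-triazol-4-yl in place of 1H-pyrazol-3-yl on a saturated chain carbon bound to an amide-type nitrogen. Going by the values given here, no measured step touches this change, so there is nothing to anchor a direction; in this assay the expected step is no change at the digits printed from compound 1 to compound 4 (within the scatter), that is none beyond the scatter. Compound 4 is therefore estimated at 69000 nM, with a range of 23000 nM to 200000 nM.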

Compound 4, half-maximal effective concentration: 7750 nM
Compound 4: the middle estimate sits 8.9-fold (0.95 log units) above what was measured; measured number outside the range, below it.
By their numbers in this assay, from the lowest: compounds 2 and 3 (each within the scatter of the next); then compound 4; then compound 1.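

For the compounds shown here, at the saturated chain carbon bound to an amide-type nitrogen, the ring itself matters: in this assay there is an 8.9-fold lower number from compound 1 to compound 4 (0.95 log units; beyond the scatter) on exchanging 1H-pyrazol-3-yl for 1H-1,2,3-triazol-4-yl, the first step at this position and one beyond the scatter. The heavy-atom count stays the same, while the entering group has one more ring nitrogen and one more hydrogen-bond acceptor. Nothing at hand explains the step.

Still open, on these data alone, is how an imidazole or a tetrazole ring would read at this place. Also open, as far as these compounds go, is whether the same exchange carries over to the core of compound 3.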